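Aryl change on the amide-type nitrogen of compound 1

The source may hold more compounds than are shown below. What is called first, only, known or untested is meant among the compounds shown, and "the series" means these compounds.

Three compounds have numbers in a functional assay on HOS-TE85 cells (Homo sapiens) for inhibition, read by CCK-8 assay, with a stated time of 72 h, tested at 1 uM; a higher number here means more inhibition at the concentration tested (going by the name of the read-out), a lower number less inhibition. Compound 1 `COc1ccc(OC)c(N2C(=O)CSC2c2cccc(C(=O)NCCCCc3ccccc3)c2)c1` gives 20% in this assay. Compound 2 `O=C(NCCCCc1ccccc1)c1cccc(C2OCC(=O)N2c2cccc(F)c2)c1` gives 87%, and compound 3 `COc1ccccc1N1C(=O)CSC1C(=O)NCCCCc1ccccc1` gives 0%. On these numbers compound 1 stands second highest of the three: its nearest neighbour is compound 3, whose number is lower by a gap beyond the usual scatter, and the furthest is compound 2, whose number is higher by a gap that is also well beyond the scatter. For the measured compounds named here, no pair among the three differs in only one place, so no single-change step can be read from the measured set; compound 2 and compound 3 are each several changes away from compound 1, and their numbers say only where they lie, not what any one change does.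

Compound 4 `COc1c(F)cccc1N1C(=O)CSC1c1cccc(C(=O)NCCCCc2ccccc2)c1` is the next compound to be measured. It differs from compound 1 in one place: 3-fluoro-2-methoxyphenyl in place of 2,5-dimethoxyphenyl on an amide-type nitrogen in a ring. The rest of compound 1 is kept. Going by the values given here, with no measured single-change step in this set to lean on, the expected step in this assay is small, a number 4 percentage points higher from compound 1 to compound 4 (within the scatter), and plausibly within the scatter. Compound 4 is therefore expected to give about 24% in this assay, within a range from 5% to 50%.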

Compound 4, a percentage reported as inhibition, at one concentration (the size of the read-out at that concentration, not a potency): 12%
Compound 4: middle estimate off by 12 percentage points, on the high side, and the stated range covers the measured number.
By their numbers in this assay, from the lowest: compound 3; then compounds 4 and 1 (each within the scatter of the next); then compound 2.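

For the compounds shown here, compound 1 and compound 4 provide the first single-change step: in this assay, the exchange of 2,5-dimethoxyphenyl for 3-fluoro-2-methoxyphenyl on the amide-type nitrogen in the ring gives a number 8 percentage points lower from compound 1 to compound 4 (within the scatter). At this position, therefore, the two aryl groups are not told apart by this read-out at the single concentration tested, while the rest of compound 1 is kept. No measurement at hand bears on why these two aryl groups read alike.

Steps linking compound 2 or compound 3 to compound 1 or compound 4 cannot be read, as each pair differs in more than one place, so what any single part of compound 2 contributes to its reading stays open. Also open, going by these compounds, is how this position would read with an amine or a carboxylic acid on the aryl ring, and whether the same aryl exchange would stay within the scatter if the four-carbon phenylbutyl chain on the amide were replaced by a longer chain.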